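A Second Fluoro Group on the Same Ring

The compounds below may be only part of what the source reports. "The series", "measured", "known", "first", "only" and "open" are said of these compounds alone.

Among the compounds with values here, compound 2 `N=C(NCCCc1c[nH]cn1)NC(=O)CC(c1ccccc1)c1ccc(F)cc1` holds, of the two numbers measured so far in a functional assay on ileum for agonist activity at histamine H1 receptor (Cavia porcellus) (a higher number here means a more potent compound, by a factor of ten per unit of this negative logarithm, a lower number a less potent compound), the one that is nominally higher: compound 2 gives 5.39. Within the data shown here, the only other measured compound, compound 1 `N=C(NCCCc1c[nH]cn1)NC(=O)CC(c1ccccc1)c1ccccc1`, gives in this assay 5.2, and the step of a number 0.19 log units higher from compound 1 to compound 2 (within the scatter) lies within the scatter, so the two compounds cannot be told apart on this read-out.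

Compound 3 `N=C(NCCCc1c[nH]cn1)NC(=O)CC(c1ccccc1)c1ccc(F)c(F)c1` has not yet been measured. It differs from compound 2 by fluoro in place of hydrogen on an aromatic carbon. Among the measured compounds shown here, the one measured step that bears on this change is a number 0.19 log units higher from compound 1 to compound 2 (within the scatter), in which a fluoro group likewise replaced a hydrogen on an aromatic carbon of the same ring and the value did not move beyond the scatter. On that basis the second fluoro group is expected to change little, the step expected from compound 2 to compound 3 being a number 0.01 log units higher from compound 2 to compound 3 (within the scatter). For compound 3 in this assay the estimate is 5.4, with a range from 5 to 5.8.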

Compound 3, negative logarithm of the half-maximal effective concentration: 6.06
Beside the measured number, compound 3's estimate is 0.66 log units below it, and the stated range ends below it.
By their numbers in this assay, from the lowest: compounds 1 and 2 (each within the scatter of the next); then compound 3.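

In this assay this position, ortho to a fluoro group and meta to a large group, responds to the change in a way the earlier pair did not show. Going from 4-fluorophenyl to 3,4-difluorophenyl gives a step beyond the scatter (a number 0.67 log units higher from compound 2 to compound 3 (beyond the scatter)), whereas the first fluoro group alone stayed within it (a number 0.19 log units higher from compound 1 to compound 2 (within the scatter)), so the same exchange of fluoro for hydrogen on an aromatic carbon does not carry one size of step from one place on this ring to the other; taken whole, 3,4-difluorophenyl in place of phenyl gives a step of similar standing (a number 0.86 log units higher from compound 1 to compound 3 (beyond the scatter)). Nothing measured here accounts for why the second fluoro group counts for more than the first.

The compounds shown leave open whether the gain is particular to fluoro or would also come with chloro, methyl or methoxy in the same place. They also leave open whether a fluoro group on the other phenyl ring would move the value any further.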